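This account rests on a few compounds, and the source may have more. Where it says the series, first, only, none or still open, it means among the compounds named here.

In an ADME assay on HEK293 cells (Homo sapiens) for cytotoxicity, read by ATP content, with a stated time of 6 h (a lower number here means that less compound is tolerated, a higher number that more compound is tolerated), compound 3 `CCC(O)CNc1nc(N)nc2ccn(Cc3ccccn3)c12` gives only a limit of the assay, > 24000 nM. Compound 1 `CCCCNc1nc(N)nc2ccn(Cc3ccccc3)c12` likewise reaches a limit, > 24000 nM. Compound 2 `CCCCNc1nc(N)nc2ccn(CCCc3ccccc3)c12` also reaches a limit, > 24000 nM. Among the compounds with values here, the single step between measured compounds that differ in one place, a step that the two limits leave unreadable from compound 1 to compound 2, is thus unreadable, and the limit of > 24000 nM in this assay, at which 3 of the 3 values shown sit, shows that every value so far rests at the same limit. Compound 4 `Cc1nc(COc2nc(N)nc3ccn(Cc4ccccn4)c23)no1` differs from compound 3 by (5-methyl-1,2,4-oxadiazol-3-yl)methoxy in place of (2-hydroxybutyl)amino on an aromatic carbon. Within the data shown here, no measured step bears on this change, and the numbers point in no direction. The step expected from this change is a step that the limit leaves unreadable from compound 3 to compound 4, none beyond the scatter. Compound 4 is therefore expected at 30000 nM, within 10000 nM to 100000 nM, most probably once more as a limit rather than a number.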

Compound 4, half-maximal cytotoxic concentration: > 24000 nM
Compound 4: no number, only a limit; the forecaster's own chance of this, stated with the estimate: 85%; the middle value is on the limit's open side.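

No new step can be read from compound 3 to compound 4, since both give only a limit: the limit of > 24000 nM in this assay, at which 4 of the 4 values shown sit.

The compounds shown leave open where any of them would fall as an actual number in this assay.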